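Hydrazide aryl swap on the shared core, activation read-out

A few compounds are considered here, and "the series" means these few. Any claim that something is new, unique, unknown or untested is made for them only; others in the source may bear on it.

Compound 2 `CCNC(=O)[C@H]1O[C@@H](n2cnc3c(NNC(=O)c4cccnc4)ncnc32)[C@H](O)[C@@H]1O` carries a pyridin-3-yl group on the carbonyl carbon of the hydrazide. In a functional assay on CHO cells for activation of adenosine receptor A2b (Homo sapiens), read by cAMP accumulation (a lower number here means that less compound is needed, a higher number that more compound is needed for the effect), compound 2 gives only a limit, > 5000 nM, and no number. Compound 1 `CCNC(=O)[C@H]1O[C@@H](n2cnc3c(NNC(=O)c4ccccc4)ncnc32)[C@H](O)[C@@H]1O` is the phenyl analogue; in this assay compound 1 likewise gives only a limit, > 5000 nM. The step from compound 1 to compound 2 is therefore a step that the two limits leave unreadable from compound 1 to compound 2. Both values sit at the same point, as summarised in the limit of > 5000 nM in this assay, at which 2 of the 2 values shown sit.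

Compound 3 `CCNC(=O)[C@H]1O[C@@H](n2cnc3c(NNC(=O)c4ccc(Br)o4)ncnc32)[C@H](O)[C@@H]1O` differs from compound 2 by 5-bromofuran-2-yl in place of pyridin-3-yl on a carbonyl carbon. For the measured compounds named here, the only measured step bearing on this position is unreadable, since it runs between two limits, so no direction can be drawn from it. With compound 1 and compound 2 both at the limit, compound 3 is expected to remain there as well, and the step from compound 2 to compound 3 is estimated as a step that the limit leaves unreadable from compound 2 to compound 3. Compound 3 is thus estimated at 8000 nM, within 2000 nM to 30000 nM, most probably reported as a limit again.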

Compound 3, half-maximal effective concentration: 369 nM
Compound 3: the middle estimate sits 22-fold (1.34 log units) above what was measured; measured number below the stated range.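

In this assay the group on the carbonyl carbon is now shown to matter: 5-bromofuran-2-yl gives an at least 13-fold lower number from compound 2 to compound 3 (1.13 log units; beyond the scatter), and in place of phenyl it gives an at least 13-fold lower number from compound 1 to compound 3 (1.13 log units; beyond the scatter). Compound 3 is the only compound shown with a number rather than a limit, so this position can carry a readable activation, which the unreadable step between the phenyl and pyridin-3-yl analogues could not show. The other two compounds remain at the limit: the limit of > 5000 nM in this assay, at which 2 of the 3 values shown sit.

The change swaps a six-membered aromatic ring for a five-membered one and also brings in bromine, and the compounds shown do not separate these two parts. Plain furan-2-yl without the bromine, or 5-chlorofuran-2-yl, would show which part carries the step.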